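A few compounds are considered here, and "the series" means these few. Any claim that something is new, unique, unknown or untested is made for them only; others in the source may bear on it.

In a functional assay on A549 cells (Homo sapiens) for cytotoxicity, with a stated time of 48 h (a higher number here means a weaker inhibitor, a lower number a stronger inhibitor), compound 1 (`CC(=O)Oc1ccc2oc(/C=C/[S+](C)[O-])cc(=O)c2c1`) gives 4100 nM, compound 2 (`CCCCCOc1ccc2oc(/C=C/[S+](C)[O-])cc(=O)c2c1`) gives 1600 nM and compound 3 (`C[S+]([O-])/C=C/c1cc(=O)c2cc(Cl)ccc2o1`) gives 1700 nM. Compound 3 thus sits level with compound 2, at a 1.1-fold higher number from compound 2 to compound 3 (0.03 log units; within the scatter), and apart from compound 1, at a 2.4-fold lower number from compound 1 to compound 3 (0.38 log units; beyond the scatter). Compound 4 (`CC(C)Oc1ccc2oc(/C=C/[S+](C)[O-])cc(=O)c2c1`) has isopropoxy in place of chloro on an aromatic carbon. The nearest evidence is compound 2, another alkyl ether, whose exchange with chloro gave only a 1.1-fold higher number from compound 2 to compound 3 (0.03 log units; within the scatter). The modest 2.6-fold lower number from compound 1 to compound 2 (0.41 log units; beyond the scatter) involved an acetyl on the oxygen, which compound 4 lacks. No step beyond the scatter is therefore expected in this assay. The expected step is a 1.1-fold higher number from compound 3 to compound 4 (0.05 log units; within the scatter). Compound 4 is estimated at 1900 nM, with an expected range of 900 nM to 4000 nM.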

Compound 4, half-maximal inhibitory concentration: 1500 nM
Beside the measured number, compound 4's estimate is 1.3-fold (0.10 log units) above it; measured number inside the range.
By their numbers in this assay, from the lowest: compounds 4, 2 and 3 (each within the scatter of the next); then compound 1.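

In this assay, isopropoxy at this position cannot be told from chloro (a 1.1-fold lower number from compound 3 to compound 4 (0.05 log units; within the scatter)), and isopropyl on the oxygen cannot be told from pentyl (a 1.1-fold lower number from compound 2 to compound 4 (0.03 log units; within the scatter)). Among the four compounds, the two alkyl ethers and chloro thus read alike, and only the acetyl compound stands apart (a 2.7-fold lower number from compound 1 to compound 4 (0.44 log units; beyond the scatter)). Nothing available here explains this. On these data alone, whether an amine or a carboxylic acid at this position would also leave the number in place stays open, as does whether a chain longer than pentyl would.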